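Benzylsulfanyl added to a nucleoside core inactive so far

This account rests on a few compounds, and the source may have more. Where it says the series, first, only, none or still open, it means among the compounds named here.

Compound 1 `Cc1nsc2c1ncn2[C@H]1C[C@H](O)[C@@H](CO)O1` was tested in a functional assay on HFF cells (Homo sapiens) for inhibition; on this read-out lower numbers stand for stronger inhibition and higher numbers for weaker inhibition. In this assay compound 1 gives only a limit, > 100000 nM. Compound 2 `CSc1nc2cnsc2n1[C@H]1C[C@H](O)[C@@H](CO)O1` also gives only a limit in this assay, > 100000 nM. Compound 3 `Cc1nsc2c1ncn2[C@@H]1O[C@H](CO)[C@@H](O)[C@@H]1O`, the starting point of the step followed here, likewise gives only a limit in this assay, > 100000 nM. Compound 3 therefore stands at the limit together with both other measured compounds, a situation summed up by the limit of > 100000 nM in this assay, at which 3 of the 3 values shown sit. Going by the values given here, the one step between measured compounds that differ in a single place, a step that the two limits leave unreadable from compound 1 to compound 3, has no readable size, so no compound can be set apart from any other and no direction of change has been seen.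

Compound 4 `Cc1nsc2c1nc(SCc1ccccc1)n2[C@@H]1O[C@H](CO)[C@@H](O)[C@@H]1O` has not yet been measured. Compared with compound 3 it carries benzylsulfanyl in place of hydrogen on an aromatic carbon. No measured step bears on this change: the only step shown is a step that the two limits leave unreadable from compound 1 to compound 3, and it carries no size. With every measured value a limit, no size of step can be expected in this assay beyond the scatter in either direction, and a further limit is the most likely outcome. Compound 4 is estimated at 150000 nM, within 20000 nM to 1000000 nM. The expected step from compound 3 is a step that the limit leaves unreadable from compound 3 to compound 4, with its meaning constrained by the limit at which compound 3 sits.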

Compound 4, half-maximal inhibitory concentration: > 100000 nM
Compound 4: a limit, no number; the forecaster's own chance of this, stated with the estimate: 70%; the middle value does not contradict the limit.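

In this assay compound 4 gives > 100000 nM as a limit only. With compound 3 also at a limit, the step between compound 3 and compound 4 cannot be read, and the picture is unchanged: the limit of > 100000 nM in this assay, at which 4 of the 4 values shown sit. The compounds shown leave open whether any change to the shared core gives a readable value in this assay at all.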